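The source may hold more compounds than are shown below. What is called first, only, known or untested is meant among the compounds shown, and "the series" means these compounds.

Measured so far:
- compound 1 `Cc1ccc(C(=O)NNC(=S)Nc2csc(-c3ccc(C)cc3)c2)cc1` gives 44000 nM
- compound 2 `COc1cc(C(=O)NNC(=S)Nc2csc(-c3ccc(C)cc3)c2)cc(OC)c1OC` gives 42000 nM

In a functional assay on SK-MEL-28 cells (Homo sapiens) for inhibition, read by colorimetric assay and MTT assay, with a stated time of 72 h (a lower number here means a stronger inhibitor, a higher number a weaker inhibitor), compound 2 gives 42000 nM, which lies within the scatter of compound 1 at 44000 nM. Compound 3 `COc1cc(OC)cc(C(=O)NNC(=S)Nc2csc(-c3ccc(C)cc3)c2)c1` is still unmeasured. It has hydrogen in place of methoxy on an aromatic carbon of compound 2, ortho to two methoxy groups and para to a large group: hydrogen in place of methoxy on an aromatic carbon. For the measured compounds named here, no step at a single place has been measured, so the only guide is these two close values. The expected change is none beyond the scatter, in either direction, with the estimated step of a 1.1-fold lower number from compound 2 to compound 3 (0.02 log units; within the scatter). For compound 3 the estimated value in this assay is 40000 nM, with an expected range of 18000 nM to 80000 nM.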

Compound 3, half-maximal inhibitory concentration: 38000 nM
Compound 3: the middle estimate sits 1.1-fold (0.02 log units) above what was measured; measured number inside the range.
By their numbers in this assay, from the lowest: compounds 3, 2 and 1 (each within the scatter of the next).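

In this assay, for the compounds shown here, the first step at a single place, hydrogen in place of methoxy on an aromatic carbon gives a 1.1-fold lower number from compound 2 to compound 3 (0.04 log units; within the scatter) and so lies within the scatter. This methoxy, ortho to two methoxy groups and para to a large group, can therefore be exchanged for hydrogen here without a readable effect on the value. Nothing available bears on an explanation of this result.

Still open, from the compounds shown here alone, is how an amine, a carboxylic acid or a longer chain such as butoxy would read at this position. Also open, going by these compounds, is whether hydrogen in place of either remaining methoxy group would give a step beyond the scatter.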